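Working notes on a selenium-bearing pair and its methyl analogue

The source may hold more compounds than are shown below. What is called first, only, known or untested is meant among the compounds shown, and "the series" means these compounds.

Measured so far:
compound 1, `CS/C(=N\C(=O)c1csc([N+](=O)[O-])c1)NC(=O)c1csc([N+](=O)[O-])c1`: in a functional assay on HepG2 cells (Homo sapiens) for cytotoxicity, read by MTT assay, with a stated time of 72 h (on this read-out lower numbers stand for higher toxicity in this test and higher numbers for lower toxicity in this test), compound 1 sits at the limit > 100000 nM
compound 2, `O=C(/N=C(/NC(=O)c1csc([N+](=O)[O-])c1)[Se]Cc1ccccc1)c1csc([N+](=O)[O-])c1`: in this assay compound 2 gives 91600 nM

Within the data shown here, compound 2 carries the only number in this assay; the one other value is a limit, (the limit of > 100000 nM in this assay, at which 1 of the 2 values shown sits). Among the measured compounds shown here, the single measured step, an at least 1.0-fold lower number from compound 1 to compound 2 (0.03 log units; that floor lies within the scatter), is a floor only, set by that limit, and cannot be read as a direction.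

Compound 3, `C[Se]/C(=N\C(=O)c1csc([N+](=O)[O-])c1)NC(=O)c1csc([N+](=O)[O-])c1`, is not yet measured. It differs from compound 2 by hydrogen in place of phenyl on a saturated chain carbon bound to a selenium atom.

The measured step bears on this change only loosely: it concerns a larger group on a carbon with a double bond to nitrogen, whereas the present change sits on a saturated chain carbon bound to a selenium atom, and its size is anyway a floor within the scatter. For the measured compounds named here, no step is therefore expected beyond the scatter in this assay, in either direction, and compound 3 is expected to show a 1.1-fold higher number from compound 2 to compound 3 (0.04 log units; within the scatter). Compound 3 is estimated at 100000 nM in this assay, with a range from 50000 nM to 200000 nM.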

Compound 3, concentration lethal to 50% of the cells: 10000 nM
For compound 3 the middle estimate is 10-fold (1.00 log units) above the measured one; the measured number lies below the stated range.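

At the saturated chain carbon bound to a selenium atom, exchanging phenyl for hydrogen has a readable effect in this assay: the step is a 9.2-fold lower number from compound 2 to compound 3 (0.96 log units; beyond the scatter), and on this read-out it points to higher toxicity for the methyl compound than for the benzyl compound. With methyl kept on both sides, the exchange of sulfur for selenium on a carbon with a double bond to nitrogen reads as an at least 10-fold lower number from compound 1 to compound 3 (1.00 log units; beyond the scatter), so a methyl group on selenium gives the lowest number of the compounds shown. That second step is only a floor, as compound 1 gives a limit and not a number: the limit of > 100000 nM in this assay, at which 1 of the 3 values shown sits.

From the compounds shown here alone, it remains open whether the step from benzyl to methyl tracks the length of the chain on selenium or the presence of the phenyl ring; an ethyl group, a longer chain or a benzyl ring carrying an amine or a carboxylic acid would separate these readings. The compounds shown also leave open the true size of the sulfur to selenium step and give no cause for either step.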